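A few compounds are considered here, and "the series" means these few. Any claim that something is new, unique, unknown or untested is made for them only; others in the source may bear on it.

Measured so far in a functional assay (HSMC cells, Homo sapiens) for antiproliferative activity, with a stated time of 72 h; on this read-out lower numbers stand for stronger inhibition and higher numbers for weaker inhibition:
- compound 1, `COC(=O)CNC(=O)c1ccc(OC[C@H]2COc3ccccc3O2)cc1-c1ccccc1OC`: 71000 nM
- compound 2, `COC(=O)CNC(=O)c1ccc(C(=O)NC[C@H]2COc3ccccc3O2)cc1-c1ccccc1OC`: 122000 nM
- compound 3, `COC(=O)CNC(=O)c1ccc(C(=O)NC[C@@H]2COc3ccccc3O2)cc1-c1ccccc1OC`: 76000 nM

Compound 3 sits second highest of the three numbers in this assay; its nearest neighbour is compound 1 and its furthest is compound 2, both gaps within the scatter. Among the compounds with values here, the only single-point step measured is a 1.6-fold lower number from compound 2 to compound 3 (0.21 log units; within the scatter), which rests on the fact that compounds 2 and 3 differ only in the configuration as drawn and carries no real change.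

Compound 4, `COC(=O)[C@H](CC(C)C)NC(=O)c1ccc(C(=O)NC[C@@H]2COc3ccccc3O2)cc1-c1ccccc1OC`, arises from compound 3 by isobutyl in place of hydrogen on a saturated chain carbon bound to an amide-type nitrogen and a carbonyl carbon. Within the data shown here, no measured step touches this position; the stereochemical step is the only one on record and it stayed inside the scatter. With nothing to point either way, no step beyond the scatter is expected for compound 4, and the estimated step of a 1.1-fold lower number from compound 3 to compound 4 (0.04 log units; within the scatter) is taken as flat. Compound 4 is therefore expected to give about 70000 nM in this assay, with a range from 25000 nM to 200000 nM.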

Compound 4, half-maximal inhibitory concentration: 469000 nM
For compound 4 the middle estimate is 6.7-fold (0.83 log units) below the measured one, outside the stated range (above it).
By their numbers in this assay, from the lowest: compounds 1, 3 and 2 (each within the scatter of the next); then compound 4.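

In this assay, the saturated chain carbon bound to an amide-type nitrogen and a carbonyl carbon responds to substitution: isobutyl in place of hydrogen there gives a 6.2-fold higher number from compound 3 to compound 4 (0.79 log units; beyond the scatter), towards weaker inhibition. Within the data shown here, the only earlier step, a 1.6-fold lower number from compound 2 to compound 3 (0.21 log units; within the scatter), concerned the configuration at a saturated ring carbon and stayed within the scatter, so this is the first position where a single change moves the read-out beyond it. Nothing on record bears on why isobutyl at this carbon has this effect.

Going by these compounds, a single substituent cannot show whether the step follows from isobutyl specifically or from any group replacing hydrogen at this carbon, so methyl, benzyl or hydroxymethyl there remain open. Also open, on these data alone, are the opposite configuration at this carbon and a carboxylic acid in place of the methyl ester.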